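Bromo in Place of Hydroxy on a Six-Membered Aromatic Ring

The source may report more compounds than this note shows. Statements on the series, on what has been measured and on what is new or still open speak of the compounds shown alone.

Compound 1 `Cc1c(C(=O)N/N=C\c2ccco2)oc2cccc(O)c12`: >= 40000 nM in a functional assay on PC-3 cells (Homo sapiens) for inhibition (a higher number here means a weaker inhibitor, a lower number a stronger inhibitor), a limit of the assay and not a number.
Compound 2 `Cc1c(C(=O)N/N=C\c2cccnc2)oc2cccc(O)c12`: >= 40000 nM in this assay, again a limit of the assay.
Compound 3 `Cc1c(C(=O)N/N=C\c2ccc(O)cc2O)oc2cccc(O)c12`: 14800 nM in this assay.

Within the data shown here, compound 3 therefore stands as the only compound of the three with a number in this assay; the other two sit at the limit of >= 40000 nM in this assay, at which 2 of the 3 values shown sit. The step that the two limits leave unreadable from compound 1 to compound 2 cannot be read, since both ends are limits. The steps of an at least 2.7-fold lower number from compound 1 to compound 3 (0.43 log units; beyond the scatter) and an at least 2.7-fold lower number from compound 2 to compound 3 (0.43 log units; beyond the scatter) show that the 2,4-dihydroxyphenyl ring gives a lower number than either five- or six-membered heteroaryl ring.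

Compound 4 `Cc1c(C(=O)N/N=C\c2ccc(Br)cc2O)oc2cccc(O)c12` keeps the shared core of compound 3 and differs from it only by bromo in place of hydroxy on an aromatic carbon. Among the measured compounds shown here, none of the measured steps bears on this change: each of them swaps the whole ring, while here the ring is kept and one substituent is exchanged for another. With no step of this kind in hand, compound 4 is expected to stay close to compound 3, a step of a 1.0-fold higher number from compound 3 to compound 4 (0.01 log units; within the scatter) that is not expected to reach beyond the scatter. The estimate for compound 4 in this assay is 15000 nM, with a range from 4000 nM to 40000 nM.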

Compound 4, half-maximal inhibitory concentration: 2050 nM
For compound 4 the middle estimate is 7.3-fold (0.86 log units) above the measured one; measured number below the stated range.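

Until now only whole rings had been exchanged, and compound 4 shows that a single substituent on a kept ring also matters: in this assay, bromo in place of hydroxy, at the place para to a large group, gives a 7.2-fold lower number from compound 3 to compound 4 (0.86 log units; beyond the scatter). This change also widens the distance from the two heteroaryl compounds, with an at least 19-fold lower number from compound 2 to compound 4 (1.29 log units; beyond the scatter) and an at least 19-fold lower number from compound 1 to compound 4 (1.29 log units; beyond the scatter), so the 4-bromo-2-hydroxyphenyl ring now has a clear lead over both the pyridin-3-yl and the furan-2-yl ring. Those two steps give only a minimum size, because compound 1 and compound 2 each rest on a limit of the assay and not on a number: the limit of >= 40000 nM in this assay, at which 2 of the 4 values shown sit.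

The compounds shown leave open whether the lower number follows from the bromo itself or from the loss of the hydroxy, a question that chloro, methoxy or an amine at the same place would help to settle. Also open, going by these compounds, is what the hydroxy group that stays on the ring contributes, since it is present in both compound 3 and compound 4.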